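The source may report more compounds than this note shows. Statements on the series, on what has been measured and on what is new or still open speak of the compounds shown alone.

Of the compounds shown here, three have so far been measured in a functional assay on KG-1 cells (Homo sapiens) for cytotoxicity, read by luminescence and CellTiter-Glo, with a stated time of 3 days; a higher number here means a weaker inhibitor, a lower number a stronger inhibitor. Compound 1 `N#Cc1cc(Cl)ccc1NC(=O)c1ccc2cccnc2c1O` gives 3540 nM; compound 2 `O=C(Nc1ccc(Cl)c(Br)c1)c1cc(Cl)ccc1O` gives 680 nM; compound 3 `N#Cc1ccc(NC(=O)c2cc(Cc3ccccc3)ccc2O)cc1` gives 1930 nM. Among these three numbers compound 3 stands second highest. Its nearest neighbour is compound 1, whose number lies within the usual scatter of its own, so the two cannot be told apart on this evidence. Compound 2 stands furthest from compound 3, with a lower number, and that gap lies beyond the scatter.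

Compound 4 `N#Cc1ccc(NC(=O)c2cc(-c3ccncc3)ccc2O)cc1` has not yet been measured in this assay. It differs from compound 3 in a single place: pyridin-4-yl in place of benzyl on an aromatic carbon. For the measured compounds named here, no pair among the measured compounds shares this change, so nothing measured shows what it is worth, and compound 1 and compound 2 carry other groups on other cores and give no guide to it either.

Lacking any comparable step, the change is expected to move the number only modestly, in no sure direction, and the step expected is a 1.3-fold higher number from compound 3 to compound 4 (0.11 log units; within the scatter). Compound 4 is therefore estimated at 2500 nM, with a range from 800 nM to 8000 nM.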

Compound 4, half-maximal inhibitory concentration: 7990 nM
For compound 4 the middle estimate is 3.2-fold (0.50 log units) below the measured one; the measured number falls inside the stated range.
By their numbers in this assay, from the lowest: compound 2; then compounds 3 and 1 (each within the scatter of the next); then compound 4.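

In this assay, the aromatic carbon para to the hydroxy group proves sensitive to what it carries: pyridin-4-yl in place of benzyl gives a 4.1-fold higher number from compound 3 to compound 4 (0.62 log units; beyond the scatter), a step beyond the scatter and the only single-place comparison among the compounds shown. Two things change together in this step, as the ring gains a hetero atom and a hydrogen-bond acceptor while the group goes from 7 heavy atoms to 6, so the single result cannot be divided between them. Nothing available bears on why the number rises with this change.

As far as these compounds go, whether the step belongs to the ring nitrogen or to the loss of benzyl stays open: a phenyl group on the same carbon would separate the two, and pyridin-3-yl would show whether the place of the nitrogen matters. Also open, from the compounds shown here alone, is how this position responds to quite different groups, such as an amine or a carboxylic acid, and whether the step would hold on the cores of compound 1 and compound 2.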